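Replacing 2-bromophenyl with 1,3-benzoxazol-2-yl on an amide

A few compounds are considered here, and "the series" means these few. Any claim that something is new, unique, unknown or untested is made for them only; others in the source may bear on it.

In a functional assay on HCT-116 cells (Homo sapiens) for inhibition, read by colorimetric assay, with a stated time of 3 days (a higher number here means a weaker inhibitor, a lower number a stronger inhibitor), compound 2 (`O=C(CCCCCCNC(=O)C(O)(O)C(F)(F)F)Nc1ccccc1Br`) gives 14500 nM as the higher of the two actual numbers, while compound 3 (`CCOc1ccc(-c2cnc(NC(=O)CCCCCCNC(=O)C(O)(O)C(F)(F)F)s2)cc1`) gives 4050 nM in a gap beyond the usual scatter. Compound 1 (`O=C(CCCCCCCNC(=O)c1cc(=O)c(O)co1)Nc1ccccc1`) reads > 100000 nM in this assay and this is a limit of the assay, not a number.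

Compound 4 (`O=C(CCCCCCNC(=O)C(O)(O)C(F)(F)F)Nc1nc2ccccc2o1`) carries 1,3-benzoxazol-2-yl in place of 2-bromophenyl on an amide-type nitrogen. Among the measured compounds shown here, no measured pair shows this change directly. For the measured compounds named here, the only guide is compound 3 at 4050 nM with another group on that nitrogen, so only a small move to a lower number is expected (a 1.8-fold lower number from compound 2 to compound 4 (0.26 log units; within the scatter)) and it may stay within the scatter. For compound 4 the estimated value is 8000 nM with an expected range from 2500 nM to 26000 nM in this assay.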

Compound 4, half-maximal inhibitory concentration: 3450 nM
The estimate for compound 4 lay 2.3-fold (0.37 log units) above the measured number, and the stated range covers the measured number.
By their numbers in this assay, from the lowest: compounds 4 and 3 (each within the scatter of the next); then compound 2. At a limit, above all of these: compound 1.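

In this assay the swap of 2-bromophenyl for 1,3-benzoxazol-2-yl on the amide-type nitrogen gives a 4.2-fold lower number from compound 2 to compound 4 (0.62 log units; beyond the scatter) and so shows directly that the group at this position can move the number. The swap changes several things at once: it adds a five-membered aromatic ring with 2 hetero atoms and brings 2 hydrogen-bond acceptors in place of 0. Nothing measured here accounts for the step.

On these data alone, it remains open whether a pyridine ring on that nitrogen would give a similar number, or whether a carboxylic acid on the benzoxazole would keep it.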